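Methylating the Amine of a Glycinamide: Expected Binding

This account rests on a few compounds, and the source may have more. Where it says the series, first, only, none or still open, it means among the compounds named here.

Three compounds share one core and differ only in the group carried on the chain that leaves its saturated ring carbon. In an assay on isolated protein for displacement of a labelled ligand from 5-hydroxytryptamine receptor 6 (Homo sapiens) (a higher number here means a weaker inhibitor, a lower number a stronger inhibitor), compound 1 `O=C(NC[C@@H]1CCCc2cc(S(=O)(=O)c3cccc(F)c3)ccc21)[C@H]1CCCN1` gives 0.631 nM, compound 2 `O=S(=O)(c1cccc(F)c1)c1ccc2c(c1)CCC[C@H]2CN1CC(O)C1` gives 0.1 nM, and compound 3 `NCC(=O)NC[C@@H]1CCCc2cc(S(=O)(=O)c3cccc(F)c3)ccc21` gives 0.316 nM. Compound 3 thus stands second highest of the three numbers: its gap to compound 1 is small, since a 2.0-fold lower number from compound 1 to compound 3 (0.30 log units; within the scatter), while a 3.2-fold higher number from compound 2 to compound 3 (0.50 log units; beyond the scatter) sets it further from compound 2, and a 6.3-fold lower number from compound 1 to compound 2 (0.80 log units; beyond the scatter).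

Compound 4 `CNCC(=O)NC[C@@H]1CCCc2cc(S(=O)(=O)c3cccc(F)c3)ccc21` arises from compound 3 by a single change, (methyl in place of hydrogen on an amine nitrogen). For the measured compounds named here, no measured step alters the amine in quite this way. The closest guide is the exchange of pyrrolidin-2-yl for aminomethyl on the carbonyl carbon, where a 2.0-fold lower number from compound 1 to compound 3 (0.30 log units; within the scatter) shows that reshaping the amine end of this chain hardly moved this assay. A similarly small effect is therefore expected, with a 1.1-fold lower number from compound 3 to compound 4 (0.02 log units; within the scatter) lying within the scatter. Compound 4 is estimated at 0.3 nM, in a range from 0.1 nM to 1 nM.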

Compound 4, inhibition constant: 0.159 nM
Compound 4: middle estimate off by 1.9-fold (0.28 log units), on the high side; low and high end bracket the measured number.
By their numbers in this assay, from the lowest: compounds 2, 4, 3 and 1 (each within the scatter of the next, the first and the last beyond it).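

In this assay a methyl on this amine nitrogen leaves the number within the scatter, as a 2.0-fold lower number from compound 3 to compound 4 (0.30 log units; within the scatter) shows, so the nitrogen accepts this small carbon group. The new compound also falls within the scatter of the 3-hydroxyazetidin-1-yl compound, with a 1.6-fold higher number from compound 2 to compound 4 (0.20 log units; within the scatter) here, whereas compound 3 stood beyond the scatter of compound 2. Set against the pyrrolidin-2-yl group, a 4.0-fold lower number from compound 1 to compound 4 (0.60 log units; beyond the scatter) lies beyond the scatter, so open-chain (methylamino)methyl and the ring group differ measurably even though the nitrogen carries a carbon substituent in both.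

From the compounds shown here alone, whether this nitrogen also tolerates a larger group, such as ethyl or a second methyl giving dimethylamino, remains open. Nothing available here explains why these numbers differ.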